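Thiophen-2-yl in place of thiophen-3-yl on the shared core

A few compounds are considered here, and "the series" means these few. Any claim that something is new, unique, unknown or untested is made for them only; others in the source may bear on it.

compound 1 `Cc1cn2c(/C=N/NC(=N)N)c(-c3ccsc3)nc2s1` gives 10200 nM in a functional assay on cells (Cancer cell lines, Homo sapiens) for inhibition; a higher number here means a weaker inhibitor of growth, a lower number a stronger inhibitor of growth
compound 2 `N=C(N)N/N=C/c1c(-c2ccsc2)nc2sccn12` gives 14800 nM in this assay

Within the data shown here, only two numbers are available, and compound 2 stands level with compound 1 within the scatter. The next structure is compound 3 `N=C(N)N/N=C/c1c(-c2cccs2)nc2sccn12`, which carries thiophen-2-yl in place of thiophen-3-yl on an aromatic carbon (see thiophen-2-yl in place of thiophen-3-yl on an aromatic carbon for the count). Among the measured compounds shown here, no measured step alters the thiophene, so the data give no direct size for this change. For the measured compounds named here, the one measured step, a 1.5-fold higher number from compound 1 to compound 2 (0.16 log units; within the scatter), is hydrogen in place of methyl at another place, and it bears on this change only indirectly. No step beyond the scatter is therefore expected in this assay, and no direction is favoured. The estimate is a 1.2-fold lower number from compound 2 to compound 3 (0.09 log units; within the scatter), which is expected to be no real change. For compound 3 the expected value is 12000 nM (estimated range 5000 nM to 30000 nM).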

Compound 3, concentration for 50% growth inhibition: 8320 nM
Estimate against measurement, compound 3: 1.4-fold (0.16 log units) above; measured number inside the range.
By their numbers in this assay, from the lowest: compounds 3, 1 and 2 (each within the scatter of the next).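

Among these compounds, the change to thiophen-2-yl in place of thiophen-3-yl gives a 1.8-fold lower number from compound 2 to compound 3 (0.25 log units; within the scatter) in this assay and provides the first direct reading at this aromatic carbon of the shared core. For compounds 2 and 3, the two thiophene attachments cannot be told apart in this read-out, so the point of attachment has no resolved effect here. Nothing available bears on the reason for this result.

Going by these compounds, whether this position accepts anything other than a thiophene remains open; a phenyl ring, an amine or a carboxylic acid on this carbon would test that. Also open, on these data alone, is whether any part of the structure can shift growth inhibition beyond the scatter, for instance a longer chain in place of the methyl of compound 1.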